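Neopentyl to tert-butyl change carried to a second core

The source may hold more compounds than are shown below. What is called first, only, known or untested is meant among the compounds shown, and "the series" means these compounds.

Compound 1 `CC(C)(C)C[C@@H](O)C(=O)N1N=CC[C@H]1C(=O)NCc1cc(Cl)ccc1-n1cnnn1` and compound 2 `CC(C)(C)[C@@H](O)C(=O)N1N=CC[C@H]1C(=O)NCc1cc(Cl)ccc1-n1cnnn1` share one core, while compound 3 `CC(C)(C)C[C@@H](O)C(=O)N1[C@@H]2C[C@@H]2C[C@H]1C(=O)NCc1cc(Cl)ccc1-n1cnnn1` and compound 4 `CC(C)(C)[C@@H](O)C(=O)N1[C@@H]2C[C@@H]2C[C@H]1C(=O)NCc1cc(Cl)ccc1-n1cnnn1` share another. The difference between the two cores is not broken down here. In an ADME assay on Caco-2 cells (Homo sapiens) for permeability, read by LC-MS, in the apical to basolateral direction, with a stated time of 60 min, at pH 6.5 (on this read-out higher numbers stand for higher permeability and lower numbers for lower permeability), compound 1 gives 24 10^-6 cm/s, compound 2 gives 15 10^-6 cm/s and compound 3 gives 24 10^-6 cm/s, level with compound 1 at the digits given.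

The change from compound 1 to compound 2 is tert-butyl in place of neopentyl on a saturated chain carbon bound to a carbonyl carbon and an oxygen on a saturated carbon. It produced a 1.6-fold lower number from compound 1 to compound 2 (0.20 log units; within the scatter).

The same change, at the same place, turns compound 3 into compound 4: tert-butyl in place of neopentyl on a saturated chain carbon bound to a carbonyl carbon and an oxygen on a saturated carbon. It occurs twice among these compounds.

In this assay compound 4 is expected to show a 1.4-fold lower number from compound 3 to compound 4 (0.15 log units; within the scatter). This rests on a 1.6-fold lower number from compound 1 to compound 2 (0.20 log units; within the scatter). Compound 4 is therefore estimated at 17 10^-6 cm/s, with a range from 10 10^-6 cm/s to 28 10^-6 cm/s.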

Compound 4, apparent permeability: 34 10^-6 cm/s
The estimate for compound 4 lay 2.0-fold (0.30 log units) below the measured number; measured number outside the range, above it.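

In this assay, tert-butyl in place of neopentyl gives a 1.4-fold higher number from compound 3 to compound 4 (0.15 log units; within the scatter), so on the core of compound 3, as on the core of compound 1, the change stays within the scatter. The two steps point in opposite directions, but the gap between them is no larger than repeated measurements allow: the same change on two cores in this assay, a 1.6-fold lower number (0.20 log units; within the scatter) from compound 1 to compound 2 and a 1.4-fold higher number (0.15 log units; within the scatter) from compound 3 to compound 4, 2.3-fold (0.36 log units) apart, within the scatter of two such steps. With one pair on each core, this shows no difference in how the two cores take the change, but it does not show that they respond alike, and it gives no rule for any other core.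

The compounds shown leave open how a longer chain or an amine at this place would read on either core. On these data alone, how the change would carry to a third core also remains open.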